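The compounds below may be only part of what the source reports. "The series", "measured", "known", "first", "only" and "open" are said of these compounds alone.

Compound 1 `O=C(O)CCc1ccc(C#Cc2cccs2)cc1` is a carboxylic acid whose core carries a triple bond to an aromatic ring. In an in vitro functional assay on 1321-N1 cells for agonist activity at Free fatty acid receptor 1 (Homo sapiens), read by fluorescence, spectrophotometry and calcium flux (a higher number here means a larger maximal response, a lower number a smaller maximal response), compound 1 reaches 97%. Compound 2 `O=C(O)CCc1ccc(C#Cc2ccc(Cl)nc2)cc1` reaches 98% in this assay. Compound 3 `O=C(O)CCc1ccc(C#Cc2cccnc2)cc1` reaches 96% in this assay, a number that sits with the other two inside the usual scatter. Two measured steps lead to compound 3: a number 1 percentage points lower from compound 1 to compound 3 (within the scatter) and a number 2 percentage points lower from compound 2 to compound 3 (within the scatter). Compound 4 `O=C(O)CCc1ccc(C#Cc2cncs2)cc1` differs from compound 3 in one place: 1,3-thiazol-5-yl in place of pyridin-3-yl on a triple-bonded carbon. The step of a number 1 percentage points lower from compound 1 to compound 3 (within the scatter) also exchanged the ring on the triple-bonded carbon, so no step beyond the scatter is expected here. For compound 4 the expected step is no change at the digits printed from compound 3 to compound 4 (within the scatter). Compound 4 is therefore expected to reach 96% in this assay, within a range from 86% to 106%.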

Compound 4, largest response reached (reported as efficacy), in percent of the reference or control that the assay uses: 99%
Estimate against measurement, compound 4: 3 percentage points below, and the stated range covers the measured number.
By their numbers in this assay, from the lowest: compounds 3, 1, 2 and 4 (each within the scatter of the next).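

With 1,3-thiazol-5-yl on the triple-bonded carbon, a ring holding both nitrogen and sulfur joins the series, and this assay gives a number 3 percentage points higher from compound 3 to compound 4 (within the scatter) and a number 2 percentage points higher from compound 1 to compound 4 (within the scatter). The ring at this place can therefore carry two hetero atoms, not just one, with no step beyond the scatter. Nothing measured here offers an explanation for these small steps. As far as these compounds go, what stays open is whether the response would hold with a non-aromatic group on the triple-bonded carbon, such as an amine or a longer alkyl chain.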